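Swapping Phenyl for an Amine Ring at One Position

The compounds below may be only part of what the source reports. "The series", "measured", "known", "first", "only" and "open" are said of these compounds alone.

Compound 1 `Cn1cc(-c2n[nH]c3ccc(N)cc23)cn1`: 8910 nM
Compound 2 `Cn1cc(-c2n[nH]c3ccc(-c4ccccc4)cc23)cn1`: 620 nM

In an assay on isolated protein for inhibition of tyrosine-protein kinase receptor UFO (Homo sapiens), with a stated time of 1.5 h (on this read-out lower numbers stand for stronger inhibition and higher numbers for weaker inhibition), compound 2 holds the lower of the two numbers. Among the compounds with values here, the only measured step, a 14-fold lower number from compound 1 to compound 2 (1.16 log units; beyond the scatter), shows that the group at this position matters strongly. Compound 3 `CNC1CCN(c2ccc3[nH]nc(-c4cnn(C)c4)c3c2)C1` carries 3-(methylamino)pyrrolidin-1-yl in place of phenyl on an aromatic carbon. Within the data shown here, no measured step covers this exact exchange. The entering group is nitrogen-linked like the amino group of compound 1, so a higher number than compound 2 is expected, though probably a smaller step than that earlier one. The estimate for compound 3 is 2500 nM, ranging from 600 nM to 10000 nM, which means an expected step of a 4.0-fold higher number from compound 2 to compound 3 (0.61 log units; beyond the scatter).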

Compound 3, half-maximal inhibitory concentration: 432000 nM
Compound 3: the middle estimate sits 170-fold (2.24 log units) below what was measured, and the stated range ends below it.
By their numbers in this assay, from the lowest: compound 2; then compound 1; then compound 3.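

Going to 3-(methylamino)pyrrolidin-1-yl in this assay brings not only a 700-fold higher number from compound 2 to compound 3 (2.84 log units; beyond the scatter) but also a 48-fold higher number from compound 1 to compound 3 (1.69 log units; beyond the scatter) and so ends up behind even the amino group. Both compound 1 and compound 3 are nitrogen-linked here, yet their numbers lie far apart, so the linking atom alone does not set the result. Nothing measured here explains this loss.

Still open, on these data alone, is whether the pyrrolidine ring or its methylamino group carries the loss. As far as these compounds go, how a morpholine ring or a pyridine ring would fare in this place also remains unknown.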